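The compounds below may be only part of what the source reports. "The series", "measured", "known", "first", "only" and "open" are said of these compounds alone.

Compound 1 `O=S(=O)(Nc1cccc2cc[nH]c12)c1ccc(Cl)cc1` is the reference point of the series; in a functional assay on P388 cells (Mus musculus) for antiproliferative activity, read by colorimetric assay and MTT assay (on this read-out lower numbers stand for stronger inhibition and higher numbers for weaker inhibition), compound 1 gives 6 ug/mL. Compound 2 `O=S(=O)(Nc1cc(Cl)cc2cc[nH]c12)c1ccc(Cl)cc1` carries chloro in place of hydrogen on an aromatic carbon; the step is a 1.7-fold higher number from compound 1 to compound 2 (0.22 log units; within the scatter), and compound 2 gives 9.9 ug/mL. Compound 3 `O=[N+]([O-])c1ccc(S(=O)(=O)Nc2cccc3cc[nH]c23)cc1` differs from compound 1 in nitro in place of chloro on an aromatic carbon; the step is a 1.4-fold higher number from compound 1 to compound 3 (0.14 log units; within the scatter), and compound 3 gives 8.2 ug/mL. Compound 2 and compound 3 lie within the scatter of each other.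

Compound 4 `O=[N+]([O-])c1ccc(S(=O)(=O)Nc2ccc(Cl)c3cc[nH]c23)cc1` is not yet measured. It stands to compound 3 as compound 2 stands to compound 1: chloro in place of hydrogen on an aromatic carbon. This is the same kind of change as that from compound 1 to compound 2, not the same, since the place differs: in compound 2 the chloro sits meta to a fused ring, meta to a large group and para to a fused ring, whereas in compound 4 it sits ortho to a fused ring, meta to a fused ring and para to a large group. The change appears in these two pairs only. The expected step is a 1.2-fold higher number from compound 3 to compound 4 (0.09 log units; within the scatter), close to the earlier one in direction and size, because the earlier step of a 1.7-fold higher number from compound 1 to compound 2 (0.22 log units; within the scatter) stayed within the scatter. Compound 4 is therefore estimated at 10 ug/mL, with a range from 5 ug/mL to 20 ug/mL.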

Compound 4, half-maximal inhibitory concentration: 3.3 ug/mL
Compound 4: middle estimate off by 3.0-fold (0.48 log units), on the high side; the measured number lies below the stated range.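

In this assay, chloro in place of hydrogen on an aromatic carbon does not carry over as a fixed step between these two cores, since it now gives a 2.5-fold lower number from compound 3 to compound 4 (0.40 log units; beyond the scatter), and the two steps do not agree: the same change on two cores in this assay, a 1.7-fold higher number (0.22 log units; within the scatter) from compound 1 to compound 2 and a 2.5-fold lower number (0.40 log units; beyond the scatter) from compound 3 to compound 4, 4.1-fold (0.61 log units) apart, beyond the scatter of two such steps. The two pairs differ in two things at once, nitro or chloro on the parent compound and the place of the added chloro, which in compound 4 is ortho to a fused ring, meta to a fused ring and para to a large group, and the data do not separate these two differences. Going by these compounds alone, with only two pairs, this shows that the step cannot be transferred here, but it gives no rule for the series and does not show which difference matters.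

Open, on these data alone, is what chloro at the place it holds in compound 4 would do on the core of compound 1, which would separate place from core. Also open, as far as these compounds go, is whether an amine or a carboxylic acid at that place would follow compound 4 or compound 2.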